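Changing the Ester Group of a Compound Tested for Adenosine Receptor A3 Binding

The compounds below may be only part of what the source reports. "The series", "measured", "known", "first", "only" and "open" are said of these compounds alone.

Compound 1 `CC1=C(C(=O)OC(C)(C)C)C(c2cccs2)NC(=O)N1` was examined in an assay on membranes from HeLa cells for displacement of a labelled ligand from adenosine receptor A3 (Homo sapiens), read by scintillation counting, with a stated time of 180 min, tested at 1 uM (on this read-out lower numbers stand for less inhibition and higher numbers for more inhibition at the one concentration tested (going by the name of the read-out)), and compound 1 gives 7%. Compound 2 `CC1=C(C(=O)OC(C)(C)C)C(c2cccs2)NC(=O)N1C` carries methyl in place of hydrogen on an amide-type nitrogen in a ring, and in this assay compound 2 gives 22%. For the measured compounds named here, the only measured step, a number 15 percentage points higher from compound 1 to compound 2 (beyond the scatter), shows a modest rise. Of the two numbers shown, compound 1 stands lowest, with compound 2 its nearest neighbour.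

Compound 3 `CC1=C(C(=O)OC2CCCC2)C(c2cccs2)NC(=O)N1` has not yet been measured. It differs from compound 1 as follows: cyclopentyl in place of tert-butyl on an oxygen next to a carbonyl group. Going by the values given here, this change concerns the ester part of the shared core, whereas the single measured step touched a ring nitrogen and left the ester unchanged, so no measured step directly informs this change. Both measured compounds show low inhibition, which anchors the expectation.

For compound 3 the expected step is a number 3 percentage points higher from compound 1 to compound 3 (within the scatter), that is, no change beyond the scatter. Compound 3 is therefore estimated to give 10% in this assay, with a range from 0% to 25%.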

Compound 3, a percentage reported as inhibition, at one concentration (the size of the read-out at that concentration, not a potency): 1%
Compound 3: middle estimate off by 9 percentage points, on the high side; the measured number falls inside the stated range.
By their numbers in this assay, from the lowest: compounds 3 and 1 (each within the scatter of the next); then compound 2.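

For the compounds shown here, this is the first measured change on the ester side of the shared core: in this assay, cyclopentyl in place of tert-butyl on an oxygen next to a carbonyl group gives a number 6 percentage points lower from compound 1 to compound 3 (within the scatter). At this place, then, a five-membered carbon ring and a tert-butyl group cannot be told apart by this read-out, although both compounds lie so close to the bottom of the scale that a further fall would be hard to see. No measurement is available that could explain this result.

On these data alone, it remains open whether an amine, a carboxylic acid or a longer chain such as n-hexyl on this oxygen would lift the number clear of the scatter. As far as these compounds go, it is also open whether methyl on the ring nitrogen, which gave a number 15 percentage points higher from compound 1 to compound 2 (beyond the scatter), would give a similar step when cyclopentyl replaces tert-butyl.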